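Cyano in place of methyl: expected half-life shift

This account rests on a few compounds, and the source may have more. Where it says the series, first, only, none or still open, it means among the compounds named here.

In an in vitro ADME assay on microsomes from liver (Simiiformes) (on this read-out lower numbers stand for a shorter-lived compound and higher numbers for a longer-lived compound), compound 1 `Cc1cc(CCCOc2c(C)cc(-c3noc(C)n3)cc2C)on1` gives 0.45 h. Compound 3 `COCc1cc(CCCOc2c(C)cc(-c3noc(C)n3)cc2C)on1` gives 0.5 h, and the methoxy change makes no difference beyond the scatter: a 1.1-fold higher number from compound 1 to compound 3 (0.05 log units; within the scatter). Compound 2 `COCc1cc(CCCOc2c(C)cc(-c3noc(C(F)(F)F)n3)cc2C)on1` gives the higher 1.58 h.

Compound 4 `Cc1cc(CCCOc2c(C)cc(-c3noc(C#N)n3)cc2C)on1` is not yet measured. It differs from compound 1 by cyano in place of methyl on an aromatic carbon, read as 5-methyl-1,2,4-oxadiazol-3-yl to 5-cyano-1,2,4-oxadiazol-3-yl: cyano in place of methyl on an aromatic carbon.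

Going by the values given here, the closest precedent is a change at this same carbon, methyl in place of trifluoromethyl, a modest step beyond the scatter: a 3.2-fold lower number from compound 2 to compound 3 (0.50 log units; beyond the scatter). Read in reverse, it puts the group other than methyl on the higher side. Among the compounds with values here, the flat methoxy step suggests it may carry over to compound 1, though no cyano example has been measured. A rise in this assay is therefore expected, somewhat smaller than the trifluoromethyl step. The expected step is a 2.0-fold higher number from compound 1 to compound 4 (0.30 log units; within the scatter). Compound 4 is estimated at 0.9 h, with an expected range of 0.4 h to 2 h.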

Compound 4, half-life: 0.283 h
For compound 4 the middle estimate is 3.2-fold (0.50 log units) above the measured one; the whole stated range lies above it.
By their numbers in this assay, from the lowest: compounds 4, 1 and 3 (each within the scatter of the next); then compound 2.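

In this assay, cyano in place of methyl on this aromatic carbon gives a 1.6-fold lower number from compound 1 to compound 4 (0.20 log units; within the scatter), so the two groups cannot be told apart here. Going by these compounds alone, a group other than methyl at this carbon therefore does not by itself bring a step beyond the scatter, and the only such step at this carbon remains the trifluoromethyl one, a 3.2-fold lower number from compound 2 to compound 3 (0.50 log units; beyond the scatter). Nothing available here bears on why cyano and trifluoromethyl read differently at this carbon.

Within the data shown here, open is whether the trifluoromethyl step holds on the core of compound 1, since that step is seen only with the methoxy-bearing core of compound 2 and compound 3. Also open, on these data alone, is how a primary amide, a chlorine atom or an ethyl group on this same carbon would read in this assay.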